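A few compounds are considered here, and "the series" means these few. Any claim that something is new, unique, unknown or untested is made for them only; others in the source may bear on it.

Measured compounds in an ADME assay on MT4 cells (Homo sapiens) for cytotoxicity, read by MTT assay, with a stated time of 4 days; on this read-out lower numbers stand for higher toxicity in this test and higher numbers for lower toxicity in this test:
- compound 1 `CCOC(=O)c1cnc(N2CCN(Cc3ccc(C#N)cc3)CC2)nc1Oc1c(C)cc(-c2ccc(C#N)cc2)cc1C`: > 125000 nM, a limit of the test rather than a number
- compound 2 `CCOC(=O)c1cnc(N2CCN(Cc3ccccc3C(=O)OC)CC2)nc1Oc1c(C)cc(-c2ccc(C#N)cc2)cc1C`: > 125000 nM, again a limit
- compound 3 `CCOC(=O)c1cnc(N2CCN(Cc3ccccc3Br)CC2)nc1Oc1c(C)cc(-c2ccc(C#N)cc2)cc1C`: > 125000 nM, again a limit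

Compound 3 stands where every compound of the series stands, at the limit of > 125000 nM in this assay, at which 3 of the 3 values shown sit; no number separates it from compound 1 or compound 2. The steps a step that the two limits leave unreadable from compound 1 to compound 2, a step that the two limits leave unreadable from compound 1 to compound 3 and a step that the two limits leave unreadable from compound 2 to compound 3 therefore carry no readable size: whatever the swap on the saturated chain carbon bound to an amine nitrogen in a ring did, the test did not resolve it.

Compound 4 `CCOC(=O)c1cnc(N2CCN(Cc3ccc(S(N)(=O)=O)cc3)CC2)nc1Oc1c(C)cc(-c2ccc(C#N)cc2)cc1C` continues the same swap: 4-sulfamoylphenyl in place of 2-bromophenyl on a saturated chain carbon bound to an amine nitrogen in a ring. The three measured steps, all unreadable, are the only ones that bear on it, and none of them shows that a change at this position moves the value out of the limit. No step beyond the scatter is expected, in either direction, in this assay; the expected outcome is that compound 4 is again reported only as a limit, and the step that the limit leaves unreadable from compound 3 to compound 4 is estimated to be nil on the shown numbers. For compound 4 the estimate is 150000 nM, in a range from 60000 nM to 400000 nM.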

Compound 4, half-maximal cytotoxic concentration: >= 7930 nM
Compound 4 was reported as a limit; the forecaster's own chance of this, stated with the estimate: 85%; the middle value lies beyond the limit too.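

In this assay compound 4 gives >= 7930 nM, a limit and not a number. Going by these compounds alone, compound 1, compound 2 and compound 3 also stand only as limits, so no step to compound 4 can be read. The compounds shown leave open whether any group on the saturated chain carbon bound to an amine nitrogen in a ring gives a number rather than a limit in this assay.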